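Inverting one ring stereocentre in a basic amide series

This account rests on a few compounds, and the source may have more. Where it says the series, first, only, none or still open, it means among the compounds named here.

The three measured compounds share a core carrying a methylated ring nitrogen and an amide-linked aromatic ring, and all three were examined in a physicochemical assay for acid dissociation. Compound 1 `COc1ccccc1C(=O)N[C@@H]1CCC[C@@H]2CCN(C)C[C@H]21` gives 8.81 in this assay. Compound 2 `COc1cc(C(=O)N[C@@H]2CCC[C@@H]3CCN(C)C[C@H]32)cc(OC)c1OC` gives 8.75 in this assay, and compound 3 `CN1CC[C@H]2CCC[C@@H](NC(=O)c3ccc(Cl)c(Cl)c3)[C@H]2C1` gives 9.05 in this assay. Compound 1 thus sits among three numbers that all lie within the usual scatter of one another, with compound 2 closest to it and compound 3 furthest away, yet even that gap stays inside the scatter.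

Compound 4 `COc1ccccc1C(=O)N[C@@H]1CCC[C@@H]2CCN(C)C[C@@H]21` has not yet been measured in this assay. It differs from compound 1 as follows: the two compounds have the same atoms and bonds and differ only in configuration as drawn: 1 of 3 stereo elements differ; a stereocentre at a saturated ring carbon is drawn S in compound 1 and R in compound 4. Among the compounds with values here, no step between two measured compounds of the same kind is available. Since the aromatic ring, the amide and the methylated ring nitrogen are untouched, a step of a number 0.04 log units higher from compound 1 to compound 4 (within the scatter) is expected, that is, none beyond the scatter. Compound 4 is therefore estimated to give 8.85 in this assay, expected between 8.55 and 9.15.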

Compound 4, acid dissociation constant: 9.11
Compound 4: middle estimate off by 0.26 log units, on the low side; low and high end bracket the measured number.
By their numbers in this assay, from the lowest: compounds 2, 1, 3 and 4 (each within the scatter of the next, the first and the last beyond it).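

Inverting the single stereocentre at a saturated ring carbon, from S to R, gives the series its first readable step at this position: a step of a number 0.30 log units higher from compound 1 to compound 4 (within the scatter) in this assay. This step can be read as one of configuration alone, because the pair offers no other difference: the fact that compounds 1 and 4 differ only in the configuration as drawn. As the step stays within the scatter, it does not establish that this inversion moves the number at all, and a repeat of these measurements could still leave the two compounds indistinguishable.

The compounds shown leave open how the remaining stereo elements behave, and whether the same inversion gives a comparable step with the aromatic rings of compound 2 or compound 3. They also leave open what an ethyl or benzyl group would do in place of the methyl on the ring nitrogen.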